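A longer hydroxycarbamoyl chain on the shared core

This account rests on a few compounds, and the source may have more. Where it says the series, first, only, none or still open, it means among the compounds named here.

Measured so far in a functional assay on HeLa cells (Homo sapiens) for inhibition, read by MTT assay, with a stated time of 72 h (a lower number here means a stronger inhibitor, a higher number a weaker inhibitor), with these results
- compound 1 `CNC(=O)CCCCCCCn1nc(-c2cnc3[nH]ccc3c2)c2c(N)ncnc21` gives 29100 nM as a number
- compound 2 `Nc1ncnc2c1c(-c1cnc3[nH]ccc3c1)nn2CCCCC(=O)NO` gives > 150000 nM as a limit

Compound 2 gives only a limit and not a number, > 150000 nM in this assay as its reading, so it stands at the limit of > 150000 nM in this assay, at which 1 of the 2 values shown sits, and has no exact position.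

Compound 3 `Nc1ncnc2c1c(-c1cnc3[nH]ccc3c1)nn2CCCCCC(=O)NO` differs from compound 2 in one place, with (hydroxycarbamoyl)methyl in place of hydroxycarbamoyl on a saturated chain carbon, four bonds along the chain from an aromatic nitrogen. The same difference reads as 3-(hydroxycarbamoyl)propyl to 4-(hydroxycarbamoyl)butyl ((hydroxycarbamoyl)methyl in place of hydroxycarbamoyl on a saturated chain carbon, four bonds along the chain from an aromatic nitrogen).

Among the compounds with values here, one measured step bears on this, an at least 5.1-fold higher number from compound 1 to compound 2 (0.71 log units; beyond the scatter) as its size, and it is an indirect guide, since it changes the end group along with the chain. Compound 1 reads 29100 nM as a number with the longer chain, so a modest move toward a stronger inhibitor is expected. A second limit remains quite possible for compound 3.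

The expected change is an at least 2.5-fold lower number from compound 2 to compound 3 (0.39 log units; beyond the scatter) as a rough estimate. Compound 3 is estimated at 60000 nM in this assay, with an expected range of 8000 nM to 150000 nM as its bounds.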

Compound 3, half-maximal inhibitory concentration: > 150000 nM
Compound 3 was reported as a limit (the forecaster's own chance of this, stated with the estimate: 40%); middle value at least 2.5-fold (0.39 log units) away from the limit.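

In this assay compound 3 gives a limit and not a number, > 150000 nM, and it shares that reading with compound 2: the limit of > 150000 nM in this assay, at which 2 of the 3 values shown sit. With limits at both ends, the step from compound 2 to compound 3 cannot be read, so the move from 3-(hydroxycarbamoyl)propyl to 4-(hydroxycarbamoyl)butyl shows no measurable gain in inhibition, though a change hidden beyond the limit cannot be excluded. The comparison that can be read is an at least 5.1-fold higher number from compound 1 to compound 3 (0.71 log units; beyond the scatter), with hydroxycarbamoyl in place of 2-(methylcarbamoyl)ethyl on a saturated chain carbon, five bonds along the chain from an aromatic nitrogen, so the longer hydroxycarbamoyl chain still leaves compound 3 a weaker inhibitor than compound 1.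

The compounds shown leave open whether a longer chain ending in hydroxycarbamoyl would give a number rather than a limit in this assay. They also leave open how far the gap to compound 1 belongs to the end group and how far to the chain length, and how a carboxylic acid or an amine at the chain end would read.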